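Ring Size at the Core: Cyclopropyl to Cyclobutyl

The source may hold more compounds than are shown below. What is called first, only, known or untested is meant among the compounds shown, and "the series" means these compounds.

Three compounds have been measured in an assay on CHO cells for displacement of a labelled ligand from melanin-concentrating hormone receptor 1 (Homo sapiens), read by scintillation counting, with a stated time of 1 h; on this read-out higher numbers stand for weaker inhibition and lower numbers for stronger inhibition:
compound 1 `Cc1nc2ccc(-n3ccc(OCc4ccc(F)cc4)cc3=O)cc2n1C` gives 77 nM;
compound 2 `CCc1nc2ccc(-n3ccc(OCc4ccc(F)cc4)cc3=O)cc2n1C` gives 48 nM;
compound 3 `Cn1c(C2CC2)nc2ccc(-n3ccc(OCc4ccc(F)cc4)cc3=O)cc21` gives 40 nM.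

Compound 3 has the lowest of the three numbers, yet its gaps to the other two lie within the scatter, so it cannot be called the strongest. Compound 4 `Cn1c(C2CCC2)nc2ccc(-n3ccc(OCc4ccc(F)cc4)cc3=O)cc21` differs from compound 3 in one place: cyclobutyl in place of cyclopropyl on an aromatic carbon. The steps that change the group on the same aromatic carbon are a 1.9-fold lower number from compound 1 to compound 3 (0.28 log units; within the scatter) and a 1.2-fold lower number from compound 2 to compound 3 (0.08 log units; within the scatter), both small; a 1.6-fold lower number from compound 1 to compound 2 (0.21 log units; within the scatter), a change on a saturated chain, is also small. Swapping one small carbon ring for a slightly larger one is therefore expected to move this assay little, if at all, roughly a 1.1-fold lower number from compound 3 to compound 4 (0.06 log units; within the scatter). Compound 4 is estimated at 35 nM, within 15 nM to 90 nM.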

Compound 4, half-maximal inhibitory concentration: 240 nM
The estimate for compound 4 lay 6.9-fold (0.84 log units) below the measured number, outside the stated range (above it).
By their numbers in this assay, from the lowest: compounds 3, 2 and 1 (each within the scatter of the next); then compound 4.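

At this aromatic carbon between two ring nitrogen atoms, the groups in compounds 1, 2 and 3 could not be told apart, but cyclobutyl gives clearly weaker inhibition in this assay (a 6.0-fold higher number from compound 3 to compound 4 (0.78 log units; beyond the scatter)). The same holds against the two open-chain or smaller groups (a 5.0-fold higher number from compound 2 to compound 4 (0.70 log units; beyond the scatter); a 3.1-fold higher number from compound 1 to compound 4 (0.49 log units; beyond the scatter)), so a single added ring carbon can matter here even though the earlier changes did not. Nothing measured here explains this drop.

From the compounds shown here alone, whether a cyclopentyl ring weakens inhibition further remains open, as does how a branched isopropyl group or an oxygen-containing oxetanyl ring would compare at this carbon.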